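This account rests on a few compounds, and the source may have more. Where it says the series, first, only, none or still open, it means among the compounds named here.

Measured so far in a functional assay on MCF7 cells (Homo sapiens) for cytotoxicity, read by sulforhodamine B assay, with a stated time of 48 h; on this read-out higher numbers stand for weaker inhibition of growth and lower numbers for stronger inhibition of growth:
Compound 1, `O=C1C(=O)N(CN2CCN(c3ccnc4cc(C(F)(F)F)ccc34)CC2)c2cccc(Br)c21`, gives 66800 nM.
Compound 2, `O=C1C(=O)N(CN2CCN(c3ccnc4cc(C(F)(F)F)ccc34)CC2)c2ccccc21`, gives 34000 nM.
Compound 3, `NC(=S)N/N=C1/C(=O)N(CN2CCN(c3ccnc4cc(Cl)ccc34)CC2)c2cc(Br)ccc21`, gives 11400 nM.

Compound 1 and compound 2 share one core and differ in a single place, (hydrogen in place of bromo on an aromatic carbon). The step that this change made is a 2.0-fold lower number from compound 1 to compound 2 (0.29 log units; within the scatter). Compound 3 is built on a different core; the difference between the two cores is not broken down here. Among the three numbers compound 3 stands lowest, with compound 2 nearest and compound 1 furthest, both gaps beyond the scatter.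

Compound 4, `NC(=S)N/N=C1/C(=O)N(CN2CCN(c3ccnc4cc(Cl)ccc34)CC2)c2ccccc21`, is not yet measured in this assay. It differs from compound 3 by hydrogen in place of bromo on an aromatic carbon. Going by the values given here, this is the same kind of change as the one from compound 1 to compound 2, not the same change: the two place descriptions differ, the bromo of compound 1 sitting ortho to a fused ring and meta to a fused ring, that of compound 3 sitting meta to a fused ring and para to a fused ring. The step from compound 3 to compound 4 is expected to be small, about a 1.6-fold lower number from compound 3 to compound 4 (0.21 log units; within the scatter), because the like change gave a 2.0-fold lower number from compound 1 to compound 2 (0.29 log units; within the scatter), and nothing in the data argues for a larger effect on the other core. Compound 4 is therefore estimated at 7000 nM, with a range from 3000 nM to 22000 nM.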

Compound 4, concentration for 50% growth inhibition: 23000 nM
Compound 4: the middle estimate sits 3.3-fold (0.52 log units) below what was measured; the measured number lies above the stated range.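

In this assay, replacing bromo with hydrogen gives a 2.0-fold higher number from compound 3 to compound 4 (0.30 log units; within the scatter), and this step cannot be assumed to carry over unchanged from the core of compound 1 to the core of compound 3: the same change on two cores in this assay, a 2.0-fold lower number (0.29 log units; within the scatter) from compound 1 to compound 2 and a 2.0-fold higher number (0.30 log units; within the scatter) from compound 3 to compound 4, 4.0-fold (0.60 log units) apart, beyond the scatter of two such steps. Taken singly, neither step lies beyond the scatter, so neither shows on its own core that the bromo matters; the only result beyond the scatter is the gap between the two steps. Going by these compounds alone, that gap rests on one pair per core and cannot be assigned to the core alone, since the bromo also sits in a different place in each pair, so it sets no rule for other compounds.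

The compounds shown leave open how the change behaves when the bromo sits in the same place on both cores, which would separate the effect of place from that of core. Also open, on these data alone, is whether a fluoro, a methoxy, an amine or a carboxylic acid on the same aromatic carbon would give steps that follow one another from core to core, or would diverge as these two do.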